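This account rests on a few compounds, and the source may have more. Where it says the series, first, only, none or still open, it means among the compounds named here.

Measured so far:
compound 1, `Cc1nc(S(C)(=O)=O)ccc1Oc1ncnc(OC2CCN(C(=O)OC(C)(C)CF)CC2)c1F`, 95%;
compound 2, `Cc1nc(S(C)(=O)=O)ccc1Oc1ncnc(OC2CCN(C(=O)SC(C)(C)C)CC2)c1F`, 76%;
compound 3, `Cc1nc(S(C)(=O)=O)ccc1Oc1ncnc(OC2CCN(C(=O)C(C)(F)F)CC2)c1F`, 87%.

In a functional assay on isolated protein for inhibition of Glucose-dependent insulinotropic receptor (Rattus norvegicus), read by HTRF and cAMP accumulation (a lower number here means a smaller maximal response, a higher number a larger maximal response), compound 3 gives 87%, the second highest of the three numbers. Its nearest neighbour is compound 1 at 95%, a gap within the scatter; compound 2 at 76% lies furthest away, and the step of a number 11 percentage points higher from compound 2 to compound 3 (beyond the scatter) is beyond the scatter, though modest.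

Compound 4, `Cc1nc(S(C)(=O)=O)ccc1Oc1ncnc(OC2CCN(C(=O)C3(F)CCC3)CC2)c1F`, has not yet been measured. It differs from compound 3 in one place: a group of 5 heavy atoms (4 carbon, 1 fluorine; one four-membered non-aromatic ring of carbon only) in place of a group of 4 heavy atoms (2 carbon, 2 fluorine; no ring), on a carbonyl carbon. All three measured steps change the same group on the carbonyl carbon: a number 19 percentage points lower from compound 1 to compound 2 (beyond the scatter), a number 8 percentage points lower from compound 1 to compound 3 (within the scatter) and a number 11 percentage points higher from compound 2 to compound 3 (beyond the scatter). None of these is large, and the two that exceed the scatter do so only modestly, so the whole set moves within a narrow band.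

On that basis compound 4 is expected to stay close to compound 3, with the step of a number 1 percentage points lower from compound 3 to compound 4 (within the scatter) estimated to lie within the scatter. The estimate for compound 4 in this assay is 86%, expected between 72% and 98%.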

Compound 4, largest response reached (reported as efficacy), in percent of the reference or control that the assay uses: 91%
Compound 4: the middle estimate sits 5 percentage points below what was measured; measured number inside the range.
By their numbers in this assay, from the lowest: compound 2; then compounds 3, 4 and 1 (each within the scatter of the next).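

In this assay, going by these compounds alone, a ring on this carbonyl carbon proves compatible with a high maximal response: the four-membered carbon ring bearing fluorine, in place of 1,1-difluoroethyl, gives a number 4 percentage points higher from compound 3 to compound 4 (within the scatter) and so leaves the response unchanged within the scatter, which no earlier compound could show. The ring also stands level with the open-chain group of compound 1, with a number 4 percentage points lower from compound 1 to compound 4 (within the scatter) as the step, while a number 15 percentage points higher from compound 2 to compound 4 (beyond the scatter) confirms that compound 2, with its (tert-butyl)sulfanyl group, is the only one of the four set apart from the others. No available evidence explains why these groups behave as they do.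

From the compounds shown here alone, whether a plain cyclobutyl, a cyclohexyl or an amine on this carbonyl carbon would keep the response remains open. The compounds shown also leave open whether the fluorine on the ring matters at all.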